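The compounds below may be only part of what the source reports. "The series", "measured", "known", "first", "only" and "open" are said of these compounds alone.

Measured set:
compound 1 `COc1ccc(F)cc1CNCCCNc1ccnc2cc(Cc3ccc(C#N)cc3)ccc12` — 23 10^-6 cm/s
compound 2 `CC(C)(C)c1ccc(Oc2ccc3c(NCCCNCc4ccco4)ccnc3c2)cc1` — 317 10^-6 cm/s
compound 3 `COc1cccc(CNCCCNc2ccnc3cc(Cc4ccc(F)cc4)ccc23)c1O` — 23 10^-6 cm/s

In an ADME assay for permeability, using PAMPA, with a stated time of 30 min, at pH 7.4 (a lower number here means that the compound crosses the layer more slowly, a higher number that the compound crosses the layer faster), compound 1 stands level with compound 3 at the digits shown, the two together the lowest of the three numbers; compound 2 sits a clear step higher, beyond the scatter. Compound 4 `COc1ccc(F)cc1CNCCCNc1ccnc2cc(CCC(C)C)ccc12` follows from compound 1 by one change: isobutyl in place of 4-cyanophenyl on a saturated chain carbon bound to an aromatic carbon. Going by the values given here, no measured pair covers this change, so no step for it is known. Among the compounds with values here, compound 2, which gives 317 10^-6 cm/s, shows only that the shared core can reach far higher numbers in this assay with other groups around it. An upward step of moderate size is expected for compound 4, a 4.3-fold higher number from compound 1 to compound 4 (0.64 log units; beyond the scatter), beyond the scatter yet short of compound 2. Compound 4 is estimated at 100 10^-6 cm/s, within 40 10^-6 cm/s to 250 10^-6 cm/s.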

Compound 4, apparent permeability: 23 10^-6 cm/s
Compound 4: middle estimate off by 4.3-fold (0.64 log units), on the high side; the measured number lies below the stated range.
By their numbers in this assay, from the lowest: compounds 1, 3 and 4 (each within the scatter of the next); then compound 2.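

In this assay there is no change at the digits printed from compound 1 to compound 4 (within the scatter) when isobutyl takes the place of 4-cyanophenyl on a saturated chain carbon bound to an aromatic carbon. In this one pair, the number at this position stays put although the aromatic ring, the nitrile and the hydrogen-bond acceptor all leave. Nothing measured here explains this. From the compounds shown here alone, whether an amine or a carboxylic acid at this place would move the number remains open, as does whether the same exchange behaves alike with other groups around the shared core.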